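The compounds below may be only part of what the source reports. "The series", "measured", "known", "first", "only" and "open" are said of these compounds alone.

Measured compounds: compound 1 `COc1cc(NCc2ccc(Cl)s2)ccc1-c1cnco1` gives 53800 nM; compound 2 `COc1cc(/N=C/c2ccncc2)ccc1-c1cnco1` gives 239000 nM; compound 3 `COc1cc(/N=C/C=C/c2ccccc2)ccc1-c1cnco1` gives 105000 nM.

All three were tested in an ADME assay on Vero cells (Chlorocebus sabaeus) for cytotoxicity, read by MTT assay, with a stated time of 96 h; on this read-out higher numbers stand for lower toxicity in this test and lower numbers for higher toxicity in this test. Compound 1 has the lowest of the three numbers. Its value and that of compound 3 lie within the scatter of each other, so no order between them can be read. Compound 2 stands beyond the scatter from compound 1, with the higher number.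

Compound 4 `COc1cc(NCc2ccc(Br)s2)ccc1-c1cnco1` has not been measured. It differs from compound 1 in one place: bromo in place of chloro on an aromatic carbon, on the 5-chlorothiophen-2-yl group, which becomes 5-bromothiophen-2-yl. For the measured compounds named here, no measured pair shows this change. Such a small exchange is expected to move the number little, if at all, so the step of a 1.1-fold lower number from compound 1 to compound 4 (0.03 log units; within the scatter) is estimated to stay within the scatter. The value for compound 4 is estimated at 50000 nM, with a range from 20000 nM to 130000 nM.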

Compound 4, half-maximal cytotoxic concentration: 47300 nM
Compound 4: middle estimate off by 1.1-fold (0.02 log units), on the high side, and the stated range covers the measured number.
By their numbers in this assay, from the lowest: compounds 4, 1 and 3 (each within the scatter of the next, the first and the last beyond it); then compound 2.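

In this assay, for the compounds shown here, this is the first pair differing in one place, and bromo in place of chloro on the 5-chlorothiophen-2-yl group gives a 1.1-fold lower number from compound 1 to compound 4 (0.06 log units; within the scatter). At this position, the two halogens therefore cannot be told apart in this test. Nothing available gives a reason for this result.

Going by these compounds, whether a methyl group or a nitrile in place of the halogen would leave the number equally undisturbed remains open. So does the effect of an amide in place of the amine linking the (5-bromothiophen-2-yl)methyl group to the core of compound 4.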